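The source may report more compounds than this note shows. Statements on the series, on what has been measured and on what is new or still open speak of the compounds shown alone.

Measured so far in this series:
Compound 1 `COc1cc2nc(N3CCC(N4CCCC4)CC3)nc(N3CCCCC3)c2cc1OC` gives 19% in an in vitro assay on B300-19 cells for displacement of a labelled ligand from C-C chemokine receptor type 4 (Homo sapiens), tested at 1 uM; a lower number here means less inhibition, a higher number more inhibition at the concentration tested (going by the name of the read-out).
Compound 2 `COc1ccc2c(NC3CCCCCC3)nc(N3CCC(N4CCCC4)CC3)nc2c1` gives 0% in this assay.
Compound 3 `COc1ccc2nc(N3CCC(N4CCCC4)CC3)nc(NC3CCCCCC3)c2c1` gives 0% in this assay.

Compound 3 stands level with compound 2 at the digits reported, and the two together are the lowest of the three numbers; the difference to compound 2 lies within the scatter, while compound 1 sits higher than compound 3 by a margin beyond the scatter.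

Compound 4 `c1ccc2c(NC3CCCCCC3)nc(N3CCC(N4CCCC4)CC3)nc2c1` differs from compound 3 in one place: hydrogen in place of methoxy on an aromatic carbon. Going by the values given here, no two measured compounds differ from each other in a single place, so no measured step stands behind this kind of change. What the numbers do show is that compound 2 and compound 3, both of which keep a methoxy on their core, give the same read-out in this assay.

Since compound 3 gives 0% in this assay, the step of a number 3 percentage points higher from compound 3 to compound 4 (within the scatter) is expected to be small, not beyond the scatter, in either direction. Compound 4 is estimated at 3% in this assay, with a range from 0% to 15%.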

Compound 4, a percentage reported as inhibition, at one concentration (the size of the read-out at that concentration, not a potency): 0%
Compound 4: the middle estimate sits 3 percentage points above what was measured, within the range that was stated.
By their numbers in this assay, from the lowest: compounds 2, 3 and 4 (each within the scatter of the next); then compound 1.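

In this assay, going by these compounds alone, hydrogen in place of methoxy on an aromatic carbon gives no change at the digits printed from compound 3 to compound 4 (within the scatter) and no change at the digits printed from compound 2 to compound 4 (within the scatter), the first single-place steps, and neither shows any effect of the methoxy at either place. Both steps start from the bottom of the read-out, with compound 2 at 0% and compound 3 at 0%, so a further loss on removing the methoxy could not appear in these numbers. No measurement on hand points to a cause for this flat result.

On these data alone, whether an amine or a carboxylic acid on this aromatic carbon would lift the read-out above that of compound 4 stays open. The higher value of compound 1 at 19% also cannot be traced to any single place in its structure.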